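Sulfanyl to bromo on a shared core, all at the limit

A few compounds are considered here, and "the series" means these few. Any claim that something is new, unique, unknown or untested is made for them only; others in the source may bear on it.

This account concerns four compounds built on a shared core. Compound 1 `OCC(CO)OCn1c(S)nc2c(Cl)cc(Cl)cc21` and compound 3 `OCC(CO)OCn1c(Br)nc2c(Cl)cc(Cl)cc21` carry one arrangement of two chloro groups, while compound 2 `OCC(CO)OCn1c(S)nc2c(Cl)c(Cl)ccc21` and compound 4 `OCC(CO)OCn1c(Br)nc2c(Cl)c(Cl)ccc21` carry another; the difference between the core of compound 1 and the core of compound 2 is not broken down here. All were examined, or remain to be examined, in a functional assay on KB cells (Homo sapiens) for inhibition; on this read-out lower numbers stand for stronger inhibition and higher numbers for weaker inhibition.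

In this assay compound 1 gives > 100000 nM, which is a limit of the assay and not a number. In this assay compound 2 likewise gives only a limit, > 100000 nM. In this assay compound 3 also sits at a limit, > 100000 nM. Within the data shown here, the change from compound 1 to compound 3 is bromo in place of sulfanyl on an aromatic carbon, and the step it made, a step that the two limits leave unreadable from compound 1 to compound 3, cannot be read because the limit of > 100000 nM in this assay, at which 3 of the 3 values shown sit, holds every value measured so far.

Compound 4 differs from compound 2 by bromo in place of sulfanyl on an aromatic carbon, the same change made at the same place. Nothing measured in this assay separates the sulfanyl analog from the bromo analog, so for compound 4 the expected step is a step that the limit leaves unreadable from compound 2 to compound 4, an expectation that rests on compound 1 and compound 3 sitting together at the limit of > 100000 nM in this assay, at which 3 of the 3 values shown sit. In this assay compound 4 is therefore estimated at 200000 nM, with the expectation that it too will most likely be reported only as a limit rather than as a number.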

Compound 4, half-maximal inhibitory concentration: > 100000 nM
Compound 4: no number, only a limit (the forecaster's own chance of this, stated with the estimate: 90%); the middle value lies beyond the limit too.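

In this assay compound 4 gives > 100000 nM, which is a limit of the assay and not a number. The step from compound 2 to compound 4 therefore cannot be read, because all the values sit together: the limit of > 100000 nM in this assay, at which 4 of the 4 values shown sit. The compounds shown leave open whether bromo and sulfanyl, or the two arrangements of chloro groups, differ at all in this assay.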